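This account rests on a few compounds, and the source may have more. Where it says the series, first, only, none or still open, it means among the compounds named here.

Measured so far:
- compound 1 `O=C(OCCO)c1nn(Cc2ccc(Cl)cc2)c2ccccc12`: 487 mg/kg
- compound 2 `O=C(OCC(O)CO)c1nn(Cc2ccc(Cl)cc2)c2ccccc12`: 503 mg/kg

In a functional assay on the whole organism (Testis, strain Long-Evans) with Rattus norvegicus as the target, with a stated time of 5 days (on this read-out higher numbers stand for an effect only at larger amounts of compound and lower numbers for an effect already at smaller amounts), compound 1 gives 487 mg/kg and compound 2 gives 503 mg/kg. For the measured compounds named here, compound 2 therefore holds the higher of the two numbers, but its only neighbour is compound 1, and the step of a 1.0-fold higher number from compound 1 to compound 2 (0.01 log units; within the scatter) lies within the scatter, so the two compounds cannot be placed in any order on this read-out.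

Compound 3 `O=C(O)Cc1nn(Cc2ccc(Cl)cc2)c2ccccc12` differs from compound 2 in one place: carboxymethyl in place of (2,3-dihydroxypropoxy)carbonyl on an aromatic carbon. Going by the values given here, the one measured step, a 1.0-fold higher number from compound 1 to compound 2 (0.01 log units; within the scatter), altered only the outer part of the ester chain and left the number essentially unchanged; it does not touch the group that is replaced here, where the whole ester is exchanged for a carboxymethyl group. Among the compounds with values here, no measured pair therefore bears directly on this change, and the expectation must rest on the observation that the one change tried so far moved nothing.

Within the data shown here, compound 3 is thus expected to give 450 mg/kg in this assay, in a range from 180 mg/kg to 1100 mg/kg, meaning an expected step of a 1.1-fold lower number from compound 2 to compound 3 (0.05 log units; within the scatter), with wide uncertainty because this change has no measured counterpart.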

Compound 3, minimum effective dose: 419 mg/kg
Compound 3: the middle estimate sits 1.1-fold (0.03 log units) above what was measured; low and high end bracket the measured number.
By their numbers in this assay, from the lowest: compounds 3, 1 and 2 (each within the scatter of the next).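

In this assay, for the compounds shown here, the exchange reaches beyond the outer part of the ester chain for the first time: the whole ester on the aromatic carbon gives way to carboxymethyl, yet the result is a 1.2-fold lower number from compound 2 to compound 3 (0.08 log units; within the scatter). Starting from the shorter ester, the exchange of (2-hydroxyethoxy)carbonyl for carboxymethyl gives a 1.2-fold lower number from compound 1 to compound 3 (0.07 log units; within the scatter), so both steps show that the read-out does not separate either ester from the carboxymethyl compound, even though the group that enters has 4 heavy atoms against the 8 of (2,3-dihydroxypropoxy)carbonyl. Nothing available bears on what lies behind this result.

The three compounds leave open whether this place on the aromatic carbon would stay as undiscriminating with an amine, an amide or a longer chain ending in a carboxylic acid. They also leave open whether any change at all moves the number in this assay, since the 4-chlorobenzyl group is the same in all three, and a benzyl group without chlorine or one bearing a methoxy group would be a different kind of test.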